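Replacing the fluoroanilide of compound 3 with a dimethoxy variant

The compounds below may be only part of what the source reports. "The series", "measured", "known", "first", "only" and "open" are said of these compounds alone.

Of the compounds shown here, three sharing one core have been measured in a functional assay on HT-29 cells (Homo sapiens) for cytotoxicity, read by MTT assay, with a stated time of 72 h; on this read-out higher numbers stand for weaker inhibition and lower numbers for stronger inhibition. Compound 1 `Fc1cc(Nc2cc(Nc3ccc(Cl)cc3)ncn2)ccc1Oc1ccncc1-c1cccnc1` gives 980 nM in this assay. Compound 2 `Fc1cc(Nc2cc(Nc3cccc(Cl)c3)ncn2)ccc1Oc1ccncc1-c1cccnc1` gives 690 nM, and compound 3 `Fc1ccc(Nc2cc(Nc3ccc(Oc4ccncc4-c4cccnc4)c(F)c3)ncn2)cc1` gives 330 nM. On these numbers compound 3 stands lowest of the three: the step of a 3.0-fold lower number from compound 1 to compound 3 (0.47 log units; beyond the scatter) and the step of a 2.1-fold lower number from compound 2 to compound 3 (0.32 log units; beyond the scatter) are both beyond the scatter, whereas the step of a 1.4-fold lower number from compound 1 to compound 2 (0.15 log units; within the scatter) is not.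

Compound 4 `COc1cc(Nc2cc(Nc3ccc(Oc4ccncc4-c4cccnc4)c(F)c3)ncn2)cc(OC)c1` differs from compound 3 in one place: 3,5-dimethoxyphenyl in place of 4-fluorophenyl on a nitrogen on an aromatic ring. Among the compounds with values here, no measured step swaps a halogen-bearing ring for a ring bearing two methoxy groups, so the only guidance comes from the changes made at this same nitrogen, where the 4-fluorophenyl to 3-chlorophenyl to 4-chlorophenyl series moved the number by modest steps at most. On that basis the change to 3,5-dimethoxyphenyl is expected to leave the number near that of compound 3, with a step of a 1.1-fold lower number from compound 3 to compound 4 (0.04 log units; within the scatter) expected, which is not beyond the scatter. Compound 4 is therefore estimated at 300 nM in this assay, with a range from 80 nM to 1200 nM to reflect the lack of any directly comparable measured step.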

Compound 4, half-maximal inhibitory concentration: 1130 nM
For compound 4 the middle estimate is 3.8-fold (0.58 log units) below the measured one; measured number inside the range.
By their numbers in this assay, from the lowest: compound 3; then compounds 2, 1 and 4 (each within the scatter of the next).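

In this assay, the group on this nitrogen proves able to move the number by more than the halogen changes alone had shown: the change to 3,5-dimethoxyphenyl gives a 3.4-fold higher number from compound 3 to compound 4 (0.53 log units; beyond the scatter) and so gives up the lowest number in the set, that of compound 3. Compared with the two chlorophenyl compounds, the new group makes no readable difference, with a 1.6-fold higher number from compound 2 to compound 4 (0.21 log units; within the scatter) and a 1.2-fold higher number from compound 1 to compound 4 (0.06 log units; within the scatter), so compound 4 falls level with each of them and 4-fluorophenyl is the only group of the four whose step to compound 4 is beyond the scatter. No evidence at hand accounts for this step or for the level standing of compound 4.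

The compounds shown leave open whether the higher number of compound 4 needs both methoxy groups, or whether a single methoxy group, a hydroxyl group or a dimethylamino group on this ring would stay level with compound 4 or come closer to compound 3. They also leave open whether a plain phenyl group would match 4-fluorophenyl or the other three groups.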